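Swapping the Aryl Group on a Boron-Bearing Scaffold

The compounds below may be only part of what the source reports. "The series", "measured", "known", "first", "only" and "open" are said of these compounds alone.

Two compounds of this series have so far been examined in an ADME assay on L929 cells (Mus musculus) for cytotoxicity, read by resazurin assay, with a stated time of 72 h; a lower number here means a stronger inhibitor, a higher number a weaker inhibitor. Compound 1 `CCCNC(=O)c1cccn1-c1ccc2c(c1)B(O)OC2` is one of them; in this assay compound 1 reaches only a limit, > 10 ug/mL. Compound 2 `O=C(c1ccn(-c2ccc3c(c2)B(O)OC3)c1)c1ccc(Cl)cc1Cl` likewise returns only a limit in this assay, namely > 10 ug/mL. Compound 2 thus stands at the limit of > 10 ug/mL in this assay, at which 2 of the 2 values shown sit, so no number places it within the range that this assay resolves. Compound 3 `Cc1ccc(C(=O)c2ccn(-c3ccc4c(c3)B(O)OC4)c2)cc1` has not yet been measured; it differs from compound 2 in one place: 4-methylphenyl in place of 2,4-dichlorophenyl on a carbonyl carbon. Among the measured compounds shown here, with both known values sitting at the limit, no step of measured size is available, and nothing in the two values shown points to a change beyond the usual scatter. The expected step in this assay is a step that the limit leaves unreadable from compound 2 to compound 3, essentially none. Compound 3 is therefore estimated in this assay at 15 ug/mL, with a range from 7 ug/mL to 40 ug/mL.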

Compound 3, half-maximal inhibitory concentration: > 10 ug/mL
Compound 3: only a limit was reported (the forecaster's own chance of this, stated with the estimate: 75%); the middle value is on the limit's open side.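

Compound 2 and compound 3 each return only a limit in this assay, so no step can be read for 4-methylphenyl in place of 2,4-dichlorophenyl on a carbonyl carbon. The compounds shown leave open where any of them would fall within the range that this assay resolves: the limit of > 10 ug/mL in this assay, at which 3 of the 3 values shown sit.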